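Swapping the piperazin-1-yl group of compound 2

This account rests on a few compounds, and the source may have more. Where it says the series, first, only, none or still open, it means among the compounds named here.

In an ADME assay on microsomes from liver (Mus musculus) for metabolic stability, read by LC-MS, using NADPH, with a stated time of 60 min, tested at 0.1 uM (on this read-out lower numbers stand for a less stable compound and higher numbers for a more stable compound), compound 1 `Fc1ccc(Nc2cc3[nH]c(Nc4ccc(N5CCNCC5)cn4)nc3cn2)cc1C(F)(F)F` gives 55% and compound 2 `Fc1ccc(Nc2cc3[nH]c(Nc4ccc(N5CCNCC5)cn4)nc3cn2)cc1F` gives 75% as the higher of the two numbers. Compound 3 `C[C@@H]1CN(c2ccc(Nc3nc4cnc(Nc5ccc(F)c(F)c5)cc4[nH]3)nc2)C[C@H](C)N1` carries 3,5-dimethylpiperazin-1-yl in place of piperazin-1-yl on an aromatic carbon and keeps the rest of compound 2. Going by the values given here, the only measured step of a number 20 percentage points higher from compound 1 to compound 2 (beyond the scatter) is modest and lies at another place, so it gives a sense of size but no direction. The expected step of a number 5 percentage points lower from compound 2 to compound 3 (within the scatter) is none beyond the scatter. In this assay the estimate for compound 3 is 70% (expected range 48% to 90%).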

Compound 3, percent of the compound remaining: 76%
Estimate against measurement, compound 3: 6 percentage points below; low and high end bracket the measured number.
By their numbers in this assay, from the lowest: compound 1; then compounds 2 and 3 (each within the scatter of the next).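

In this assay, 3,5-dimethylpiperazin-1-yl in place of piperazin-1-yl gives a number 1 percentage points higher from compound 2 to compound 3 (within the scatter). Going by these compounds alone, this is the first measured change at this position, on an aromatic carbon para to a large group, and the larger group with its 2 defined stereocentres leaves the number within the scatter. Nothing at hand speaks to the reason for this result.
As far as these compounds go, whether a morpholine or a dimethylamino group at this place would read the same remains open. So does whether this swap would read alike on compound 1, which carries trifluoromethyl.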